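Swapping a naphthalene for chlorophenyl on the shared core

This account rests on a few compounds, and the source may have more. Where it says the series, first, only, none or still open, it means among the compounds named here.

Compound 1 `CC1(C)S[C@@H]2/C(=C\C(=O)c3ccc4ccccc4c3)C(=O)N2[C@H]1C(=O)OC(c1ccccc1)c1ccccc1` stands second highest of the three numbers in a functional assay on A-375 cells (Homo sapiens) for cytotoxicity, read by MTT assay, with a stated time of 48 h (a lower number here means a stronger inhibitor, a higher number a weaker inhibitor), where compound 1 gives 36500 nM. Compound 2 `CC1(C)S[C@@H]2/C(=C\C(=O)c3ccc([N+](=O)[O-])cc3)C(=O)N2[C@H]1C(=O)OC(c1ccccc1)c1ccccc1` gives 50300 nM, and compound 3 `CC1(C)S[C@@H]2/C(=C\C(=O)OCc3ccccc3)C(=O)N2[C@H]1C(=O)OC(c1ccccc1)c1ccccc1` gives 7100 nM. The change to compound 4 `CC1(C)S[C@@H]2/C(=C\C(=O)c3ccc(Cl)cc3)C(=O)N2[C@H]1C(=O)OC(c1ccccc1)c1ccccc1` is 4-chlorophenyl in place of naphthalen-2-yl on a carbonyl carbon. The nearest measured step is the same swap for another single aromatic ring: a 1.4-fold higher number from compound 1 to compound 2 (0.14 log units; within the scatter). The other steps, a 5.1-fold lower number from compound 1 to compound 3 (0.71 log units; beyond the scatter) and a 7.1-fold lower number from compound 2 to compound 3 (0.85 log units; beyond the scatter), replace the aromatic ring with benzyloxy and so bear less on this change. In this assay a step within the scatter is therefore expected, with no clear direction. Compound 4 is expected to give about 40000 nM, in the range 18000 nM to 90000 nM. The expected step is a 1.1-fold higher number from compound 1 to compound 4 (0.04 log units; within the scatter).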

Compound 4, half-maximal inhibitory concentration: 48600 nM
The estimate for compound 4 lay 1.2-fold (0.08 log units) below the measured number; measured number inside the range.
By their numbers in this assay, from the lowest: compound 3; then compounds 1, 4 and 2 (each within the scatter of the next).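

In this assay, 4-chlorophenyl on this carbonyl carbon cannot be told apart from the two earlier aromatic groups, with a 1.3-fold higher number from compound 1 to compound 4 (0.12 log units; within the scatter) and a 1.0-fold lower number from compound 2 to compound 4 (0.01 log units; within the scatter) both small. A third aromatic group also stays well separated from benzyloxy, with a 6.8-fold higher number from compound 3 to compound 4 (0.84 log units; beyond the scatter) as the step, so among these compounds only benzyloxy stands apart. No measurement offered here explains that gap. From the compounds shown here alone, it remains open whether a smaller ethoxy group in place of benzyloxy would keep compound 3's stronger result. Going by these compounds, it also remains open whether an amine on the aromatic ring would separate from these three aromatic groups.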